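Thiophen-2-yl for pyridin-2-yl: from compound 2 to compound 4

This account rests on a few compounds, and the source may have more. Where it says the series, first, only, none or still open, it means among the compounds named here.

Three related compounds have been measured in a physicochemical assay, with a stated time of 30 min (a lower number here means a stronger inhibitor, a higher number a weaker inhibitor), so far. Compound 1 `C/C(=N\N=C1/SCC(=O)N1Cc1cccc(F)c1)c1cccs1` gives 21100000 nM, compound 2 `C/C(=N/N=C1\SCC(=O)N1Cc1ccc(F)cc1)c1ccccn1` gives 16200000 nM and compound 3 `CC(C)=N/N=C1\SCC(=O)N1Cc1ccc(N)cc1` gives 2040000 nM on this scale. Compound 2 therefore stands within the scatter of compound 1, while compound 3 has a clearly lower number, which marks it as the stronger inhibitor of that pair.

Compound 4 `C/C(=N/N=C1\SCC(=O)N1Cc1ccc(F)cc1)c1cccs1` has not yet been measured. It differs from compound 2 in one place: thiophen-2-yl in place of pyridin-2-yl on a carbon with a double bond to nitrogen. In words, thiophen-2-yl stands in place of pyridin-2-yl on a carbon with a double bond to nitrogen.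

Going by the values given here, no measured pair shows this swap directly. Compound 1 also carries thiophen-2-yl and gives 21100000 nM, a value within the scatter of compound 2, so no change beyond the scatter is expected in this assay. The estimated step of a 1.1-fold higher number from compound 2 to compound 4 (0.05 log units; within the scatter) is therefore small, and its direction is uncertain. In this assay the estimate for compound 4 is 18000000 nM, with an expected range from 8000000 nM to 40000000 nM.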

Compound 4, half-maximal inhibitory concentration: 21500000 nM
Estimate against measurement, compound 4: 1.2-fold (0.08 log units) below; measured number inside the range.
By their numbers in this assay, from the lowest: compound 3; then compounds 2, 1 and 4 (each within the scatter of the next).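

In this assay, going by these compounds alone, this is the first direct comparison at this position, a 1.3-fold higher number from compound 2 to compound 4 (0.12 log units; within the scatter), and the step lies within the scatter. On a carbon with a double bond to nitrogen, thiophen-2-yl in place of pyridin-2-yl therefore gives no change that can be told apart from the spread of repeated measurements, at least for this one pair with the rest of the structure held fixed. No measured evidence is available to explain this result.

As far as these compounds go, it remains open whether a group of a different kind on this carbon, such as an amine or a carboxylic acid, would shift the number beyond the scatter. From the compounds shown here alone, compound 3 differs from compound 2 in more than one place, so the source of its lower number also remains open.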